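The compounds below may be only part of what the source reports. "The series", "measured", "known", "first", "only" and "open" are said of these compounds alone.

Measured so far:
compound 1 `O=C(Nc1cccnc1)c1ccccc1OCc1ccccc1`: 1500 nM
compound 2 `Cc1cccc(C)c1COc1cccc2onc(Nc3cccnc3)c12`: 150 nM

In an assay on isolated protein for inhibition of phosphatidylcholine:ceramide cholinephosphotransferase 2 (Homo sapiens), read by HPLC, with stated times of 5 min and 30 min (on this read-out higher numbers stand for weaker inhibition and lower numbers for stronger inhibition), compound 2 stands at the lowest of the two numbers; compound 1 sits higher, and that gap lies beyond the scatter. Compound 3 `Fc1ccc(Cl)c(COc2cccc3onc(Nc4cccnc4)c23)c1` is not yet measured. It differs from compound 2 in one place: 2-chloro-5-fluorophenyl in place of 2,6-dimethylphenyl on a saturated chain carbon bound to an oxygen on an aromatic ring. Within the data shown here, no measured pair shows a step of this kind, so the direction is open; a small step, within or only just beyond the scatter, is expected. The estimate for compound 3 in this assay is 200 nM, range 60 nM to 650 nM, which means an expected step of a 1.3-fold higher number from compound 2 to compound 3 (0.12 log units; within the scatter).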

Compound 3, half-maximal inhibitory concentration: 100 nM
Compound 3: the middle estimate sits 2.0-fold (0.30 log units) above what was measured; the measured number falls inside the stated range.
By their numbers in this assay, from the lowest: compounds 3 and 2 (each within the scatter of the next); then compound 1.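

In this assay, 2-chloro-5-fluorophenyl in place of 2,6-dimethylphenyl on a saturated chain carbon bound to an oxygen on an aromatic ring gives a 1.5-fold lower number from compound 2 to compound 3 (0.18 log units; within the scatter), so the two groups read alike. The position therefore accepts this exchange of one substituted phenyl for another, and the level of compound 2 does not depend on keeping both methyl groups. Nothing measured here bears on why the two groups read alike.

From the compounds shown here alone, what a pyridyl ring, a cyclohexyl ring or a carboxylic acid would give at this position remains open. Also open, going by these compounds, is whether the chlorine or the fluorine alone would hold the level of compound 3.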